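The compounds below may be only part of what the source reports. "The series", "measured", "known", "first", "only" and "open" are said of these compounds alone.

Compound 1, `Cc1ccc(S(=O)(=O)N[C@@H]2CC[C@@H](O)[C@H]2C/C=C\CCCC(=O)O)cc1`, sits at the weak end of what has been measured here. In a functional assay (plasma) for inhibition, with Homo sapiens as the target (a higher number here means a weaker inhibitor, a lower number a stronger inhibitor), compound 1 gives 5800 nM, the highest of the three numbers. Compound 2, `C[C@@H]1CC/C(=N\OC(c2ccccc2)c2ccccc2)[C@H]1C/C=C\CCCC(=O)O`, gives 800 nM in this assay, and compound 3, `Cc1ccc(S(=O)(=O)N[C@H]2CC/C(=N\OCC3CCCCC3)[C@@H]2C/C=C\CCCC(=O)O)cc1`, gives 600 nM; both of these lie below compound 1 by more than the usual scatter, so compound 1 is the weakest inhibitor of the three. Compound 2 and compound 3 are not related to compound 1 by any single change, so they set the range but not the direction of a step.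

Compound 4, `O=C(O)CCC/C=C\C[C@@H]1[C@H](O)CC[C@H]1NS(=O)(=O)c1ccc(Cl)cc1`, is not yet measured. It differs from compound 1 by chloro in place of methyl on an aromatic carbon. Within the data shown here, no measured pair shows this exchange, so the expected step from compound 1 is small: the step of a 1.5-fold lower number from compound 1 to compound 4 (0.16 log units; within the scatter) is estimated to stay within the scatter, if anything a slight lowering. Compound 4 is therefore expected to give about 4000 nM in this assay, between 1500 nM and 12000 nM.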

Compound 4, half-maximal inhibitory concentration: 2200 nM
Compound 4: middle estimate off by 1.8-fold (0.26 log units), on the high side; the measured number falls inside the stated range.
By their numbers in this assay, from the lowest: compounds 3 and 2 (each within the scatter of the next); then compound 4; then compound 1.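

Going from 4-methylphenyl to 4-chlorophenyl gives the first single-change comparison in this assay, and it amounts to a 2.6-fold lower number from compound 1 to compound 4 (0.42 log units; beyond the scatter). This shows that the place on the aromatic ring para to a large group is not indifferent to the exchange of one heavy atom for another, and that chloro gives the stronger inhibitor of this pair. Nothing available here accounts for the size or direction of this step.

The compounds shown leave open how other groups at this place, such as fluoro, methoxy or trifluoromethyl, or plain hydrogen, would compare with methyl and chloro. They also leave open whether chloro would give a similar step on the core of compound 3, which carries the same 4-methylphenyl group.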